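Aminoacetamide ketones: ethylamino to dimethylamino on two cores

The source may hold more compounds than are shown below. What is called first, only, known or untested is meant among the compounds shown, and "the series" means these compounds.

compound 1 `CCNCC(=O)Nc1cc(OC)ccc1C(=O)c1ccc(OC)c2c1C=CC(C)(C)O2` — 4270 nM
compound 2 `COc1ccc(C(=O)c2ccc(OC)c3c2C=CC(C)(C)O3)c(NC(=O)CN(C)C)c1` — 3620 nM
compound 3 `CCNCC(=O)Nc1cc(OC)ccc1C(=O)c1cc(OC)c(OC)c(OC)c1` — 2100 nM

All three numbers come from a functional assay on HeLa cells (Homo sapiens) for antiproliferative activity, read by MTT assay, with a stated time of 48 h; on this read-out lower numbers stand for stronger inhibition and higher numbers for weaker inhibition. Compound 1 and compound 2 share one core and differ only in the side chain: dimethylamino in place of ethylamino on a saturated chain carbon bound to a carbonyl carbon. The step is a 1.2-fold lower number from compound 1 to compound 2 (0.07 log units; within the scatter), so on this core the exchange leaves the read-out essentially where it was.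

Compound 3 carries a different core; the difference between the two cores is not broken down here. Compound 3 has the lowest number of the three. Against compound 2 the gap is within the scatter, so no order between them is claimed; against compound 1 the gap is beyond the scatter.

Compound 4 `COc1ccc(C(=O)c2cc(OC)c(OC)c(OC)c2)c(NC(=O)CN(C)C)c1` is not yet measured in this assay. It relates to compound 3 exactly as compound 2 relates to compound 1: dimethylamino in place of ethylamino on a saturated chain carbon bound to a carbonyl carbon, and the place is the same in both pairs, so it is the same change. Within the data shown here, the only measured instance of this change is the step from compound 1 to compound 2, which is a 1.2-fold lower number from compound 1 to compound 2 (0.07 log units; within the scatter). On that basis the step from compound 3 to compound 4 is expected to be small, about a 1.2-fold lower number from compound 3 to compound 4 (0.07 log units; within the scatter), because the earlier pair gave a 1.2-fold lower number from compound 1 to compound 2 (0.07 log units; within the scatter). Compound 4 is therefore estimated at 1800 nM in this assay, with a likely range from 900 nM to 3600 nM; the uncertainty rests on a single prior example of the change and on the scatter of compound 3 at 2100 nM.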

Compound 4, half-maximal inhibitory concentration: 470 nM
For compound 4 the middle estimate is 3.8-fold (0.58 log units) above the measured one; measured number below the stated range.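

In this assay, on the core of compound 3, dimethylamino in place of ethylamino on a saturated chain carbon bound to a carbonyl carbon gives a 4.5-fold lower number from compound 3 to compound 4 (0.65 log units; beyond the scatter). The size of the step therefore did not carry over from the core of compound 1 to the core of compound 3, and the two cores have to be treated separately for this change: the same change on two cores in this assay, a 1.2-fold lower number (0.07 log units; within the scatter) from compound 1 to compound 2 and a 4.5-fold lower number (0.65 log units; beyond the scatter) from compound 3 to compound 4, 3.8-fold (0.58 log units) apart, beyond the scatter of two such steps. This shows that the outcome of the exchange depends on the core in these two pairs, but with one pair per core it gives no rule for a third core and does not show which structural difference between the two cores accounts for the gap, or by what mechanism.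

Still open, going by these compounds, is whether the lower number on the core of compound 3 is particular to dimethylamino or extends to other amines in the same place, such as a primary amine, diethylamino, pyrrolidine or morpholine. Also open, on these data alone, is whether a longer chain between the amide carbonyl and the amine would keep that lower number, and whether the same exchange on a further core would resemble either of the two steps seen so far.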